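Methyl for Chloro on the Amide Aryl Ring of Compound 1

The source may report more compounds than this note shows. Statements on the series, on what has been measured and on what is new or still open speak of the compounds shown alone.

Compound 1, `O=C(c1ccc(Cl)cc1)N1CC(c2nc(-c3cccc(F)c3)no2)C1`: in an assay on HEK293 cells for negative allosteric modulation of metabotropic glutamate receptor 5 (Homo sapiens), read by FLIPR (a higher number here means a weaker inhibitor, a lower number a stronger inhibitor), compound 1 gives > 10000 nM, which is a limit of the assay and not a number.
Compound 2, `O=C(c1ccccc1F)N1CC[C@H]1c1nc(-c2cccc(F)c2)no1`: in this assay compound 2 gives 920 nM.
Compound 3, `Cc1cccc(-c2noc(C3CN(C(=O)C4CCC(C(F)(F)F)CC4)C3)n2)c1`: in this assay compound 3 gives > 10000 nM, again a limit and not a number.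

Among the compounds with values here, compound 1 therefore stands at the limit of > 10000 nM in this assay, at which 2 of the 3 values shown sit, so no step from it to another measured compound can be sized; compound 2 alone carries a number, and it differs from compound 1 in more than one place, so the two values show only that compound 2 is the one with a measured inhibition.

Compound 4, `Cc1ccc(C(=O)N2CC(c3nc(-c4cccc(F)c4)no3)C2)cc1`, is not yet measured. It differs from compound 1 by methyl in place of chloro on an aromatic carbon, with the rest of the shared core unchanged.

No measured step of this kind is shown, so the size of the step to compound 4 in this assay cannot be read from data. With compound 1 at a limit and compound 3 also at a limit, the expectation for compound 4 is that it again sits near or beyond the limit, with a step that the limit leaves unreadable from compound 1 to compound 4 expected to be within scatter rather than a clear change. Compound 4 is estimated at 12000 nM, within 3000 nM to 50000 nM.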

Compound 4, half-maximal inhibitory concentration: > 10000 nM
Compound 4: only a limit was reported; the forecaster's own chance of this, stated with the estimate: 60%; the middle value is on the limit's open side.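

In this assay compound 4 gives > 10000 nM, a limit of the assay and not a number, and compound 1 also stands at a limit, so no step between them can be read: the limit of > 10000 nM in this assay, at which 3 of the 4 values shown sit.

The compounds shown leave open how far methyl in place of chloro shifts inhibition, and which of its several differences from compound 1 goes with the value of compound 2, 920 nM.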